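Pendant aryl substituent and cytotoxicity on the shared core

This account rests on a few compounds, and the source may have more. Where it says the series, first, only, none or still open, it means among the compounds named here.

Of the compounds shown here, three on a shared core have been measured in an ADME assay on MT4 cells (Homo sapiens) for cytotoxicity, read by MTT assay, with a stated time of 4 days; on this read-out lower numbers stand for higher toxicity in this test and higher numbers for lower toxicity in this test. Compound 1 `COc1ccccc1-c1cc(C)c(Nc2ccnc(Nc3ccc(C#N)cc3)n2)c(C)c1` gives 940 nM, compound 2 `COc1cccc(-c2cc(C)c(Nc3ccnc(Nc4ccc(C#N)cc4)n3)c(C)c2)c1` gives 2990 nM, and compound 3 `Cc1cc(-c2c(C)cccc2C)cc(C)c1Nc1ccnc(Nc2ccc(C#N)cc2)n1` gives 2590 nM. Compound 2 stands highest of the three numbers: a 3.2-fold higher number from compound 1 to compound 2 (0.50 log units; beyond the scatter), and a 2.8-fold higher number from compound 1 to compound 3 (0.44 log units; beyond the scatter), whereas a 1.2-fold lower number from compound 2 to compound 3 (0.06 log units; within the scatter).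

The next compound, compound 4 `Cc1cc(-c2cccc(C(F)(F)F)c2)cc(C)c1Nc1ccnc(Nc2ccc(C#N)cc2)n1`, differs from compound 2 in one place: trifluoromethyl in place of methoxy on an aromatic carbon. Going by the values given here, no measured step swaps these two groups, so only indirect evidence bears on it. Both steps that start from compound 1 show that changing the substitution of the pendant ring can move the number modestly; the step from compound 2 to compound 3, which replaces the whole 3-methoxyphenyl, stays within the scatter. Compounds 2 and 3 thus suggest that the number does not depend sharply on which group sits on this ring, while compound 1 shows that some changes there do register. For compound 4 the expected step is a 1.2-fold lower number from compound 2 to compound 4 (0.10 log units; within the scatter), that is, no step beyond the scatter, with the number, if anything, expected slightly lower. Compound 4 is estimated at 2400 nM, within 1000 nM to 6000 nM.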

Compound 4, half-maximal cytotoxic concentration: 4030 nM
Estimate against measurement, compound 4: 1.7-fold (0.23 log units) below, and the stated range covers the measured number.
By their numbers in this assay, from the lowest: compound 1; then compounds 3, 2 and 4 (each within the scatter of the next).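

Going by these compounds alone, exchanging methoxy for trifluoromethyl on an aromatic carbon meta to a large group gives the first direct reading of a group swap at this position in this assay, and it stays within the scatter, with a 1.3-fold higher number from compound 2 to compound 4 (0.13 log units; within the scatter). Within the data shown here, compound 4 also cannot be separated from compound 3, with a 1.6-fold higher number from compound 3 to compound 4 (0.19 log units; within the scatter), while the widest step so far is a 4.3-fold higher number from compound 1 to compound 4 (0.63 log units; beyond the scatter), so compounds 2, 3 and 4 form one cluster and compound 1, with its 2-methoxyphenyl, is the only one that stands apart. No measurement is at hand that would explain why this swap registers so little or why compound 1 differs.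

Open, on these data alone, is whether the cluster holds for a group of another kind on the same carbon, such as an amine or a carboxylic acid, or for an unsubstituted phenyl, which would give a reference point for all four pendant rings. Also open, as far as these compounds go, is whether the separate position of compound 1 belongs to methoxy alone, since the 2,6-dimethylphenyl of compound 3 stays in the cluster.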